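This account rests on a few compounds, and the source may have more. Where it says the series, first, only, none or still open, it means among the compounds named here.

Measured in a functional assay on HT-29 cells (Homo sapiens) for inhibition (a lower number here means a stronger inhibitor, a higher number a weaker inhibitor), so far:
compound 1 `COCCOc1cc(/C=C\c2ccc3ccccc3c2)ccc1OC` gives 2990 nM as a number
compound 2 `COc1ccc(/C=C/c2ccc3ccccc3c2)cc1` gives > 5000 nM as a limit
compound 3 `COc1ccc(/C=C/c2ccc3ccccc3c2)cc1[N+](=O)[O-]` gives > 5000 nM as a limit

Compound 3 therefore has no number, only the limit > 5000 nM in this account. Compound 2 shares that place, and the position is the limit of > 5000 nM in this assay, at which 2 of the 3 values shown sit, in short.

Compound 4 `COc1ccc(/C=C\c2ccc3ccccc3c2)cc1[N+](=O)[O-]` comes from compound 3 by one change, the two compounds have the same atoms and bonds and differ only in configuration as drawn: 1 of 1 stereo elements differ; a double bond is drawn E in compound 3 and Z in compound 4 and nothing else. Among the compounds with values here, no measured step shows this change alone. Within the data shown here, the only step between measured compounds is a step that the two limits leave unreadable from compound 2 to compound 3 and it concerns a nitro group, not the double bond. The nearest guide is compound 1 at 2990 nM with its double bond drawn Z, although it also differs in other groups. A move toward stronger inhibition in this assay is thus expected, of uncertain size. The expected step is an at least 2.5-fold lower number from compound 3 to compound 4 (0.39 log units; beyond the scatter) on this reasoning. Compound 4 is estimated at 2000 nM with an expected range from 300 nM to 8000 nM in this assay.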

Compound 4, half-maximal inhibitory concentration: 3280 nM
Estimate against measurement, compound 4: 1.6-fold (0.21 log units) below, and the stated range covers the measured number.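

Setting the double bond Z instead of E takes the nitro compound off the limit in this assay and gives it a number, with an at least 1.5-fold lower number from compound 3 to compound 4 (0.18 log units; that floor lies within the scatter). Nothing else varies in this pair, so the step belongs to the double bond alone: the fact that compounds 3 and 4 differ only in the configuration as drawn

With the double bond drawn Z in both compounds, nitro and 2-methoxyethoxy on the aromatic carbon are not told apart, with a 1.1-fold higher number from compound 1 to compound 4 (0.04 log units; within the scatter).

On these data alone, the step from compound 2 to compound 3 cannot be read, so what the nitro group does with the double bond drawn E stays open: the limit of > 5000 nM in this assay, at which 2 of the 4 values shown sit. Also open is whether an amine or a carboxylic acid on that aromatic carbon, with the double bond drawn Z, would give a number different from that of compound 4.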